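The compounds below may be only part of what the source reports. "The series", "measured", "known", "first", "only" and "open" are said of these compounds alone.

Measured compounds:
`C=C1CC(Cn2cc(C)c(=O)[nH]c2=O)(c2ccc(-c3ccccc3)cc2)OC1=O` compound 1, 646 nM
`C=C1CC(Cn2cc(C)c(=O)[nH]c2=O)(c2ccc(F)cc2)OC1=O` compound 2, 3550 nM

In a functional assay on RPMI-8226 cells (Homo sapiens) for inhibition (a lower number here means a stronger inhibitor of growth, a higher number a weaker inhibitor of growth), compound 1 gives the lowest of the two numbers; the nearest is compound 2, reached by a 5.5-fold higher number from compound 1 to compound 2 (0.74 log units; beyond the scatter) with fluoro in place of phenyl on an aromatic carbon.

Compound 3 `C=C1CC(Cn2ccc(=O)[nH]c2=O)(c2ccc(-c3ccccc3)cc2)OC1=O` is not yet measured. It differs from compound 1 by hydrogen in place of methyl on an aromatic carbon. For the measured compounds named here, the one measured step concerns a change on the other aromatic ring, the phenyl-bearing one, and does not touch the ring carrying the methyl; no step among the measured compounds bears directly on the present change. The change is small in count, one carbon removed, and the rest of the molecule is kept. The expectation is therefore a step of at most modest size, likely within the scatter, with no direction to be inferred from the data.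

Compound 3 is estimated at 900 nM, in the range 250 nM to 3500 nM, meaning an expected step of a 1.4-fold higher number from compound 1 to compound 3 (0.14 log units; within the scatter).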

Compound 3, concentration for 50% growth inhibition: 214 nM
Compound 3: the middle estimate sits 4.2-fold (0.62 log units) above what was measured, and the stated range ends above it.
By their numbers in this assay, from the lowest: compound 3; then compound 1; then compound 2.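

In this assay, the methyl on the six-membered aromatic ring with 2 nitrogen is not required for growth inhibition: replacing it with hydrogen gives a 3.0-fold lower number from compound 1 to compound 3 (0.48 log units; beyond the scatter). The earlier step covered only the other aromatic ring, so this is the first sign that the position two atoms from the ring nitrogen also affects the read-out, with hydrogen favoured over methyl in the biphenyl-bearing compounds shown. Nothing available explains this step.

The compounds shown hold only hydrogen and methyl at this position, so it remains open whether a chlorine, an ethyl chain or an amine would continue the direction or reverse it. On these data alone, it is also open whether the step seen with fluoro in place of phenyl would hold with hydrogen at this position.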